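The compounds below may be only part of what the source reports. "The series", "measured", "known", "first", "only" and "open" are said of these compounds alone.

In a functional assay on U-251 cells (Homo sapiens) for inhibition, read by sulforhodamine B assay, with a stated time of 48 h (on this read-out higher numbers stand for weaker inhibition of growth and lower numbers for stronger inhibition of growth), two compounds built on a shared core have been measured so far. Compound 1 `CCOC(=O)C1=C(C)NC(=O)NC1c1ccc(SC)cc1` gives 8 ug/mL, and compound 2 `CCCc1ccc(C2NC(=O)NC(C)=C2C(=O)OCC)cc1` gives 35.4 ug/mL, the higher of the two numbers and so the weaker inhibition of growth. Compound 3 `CCOC(=O)C1=C(C)NC(=O)NC1c1ccc(O)cc1` has not yet been measured. It differs from compound 2 in one place, with hydroxy in place of propyl on an aromatic carbon, para to a large group (hydroxy in place of propyl on an aromatic carbon). Going by the values given here, only one measured step bears on this change: a 4.4-fold higher number from compound 1 to compound 2 (0.65 log units; beyond the scatter), a modest step that came with propyl in place of methylsulfanyl on an aromatic carbon. Among the compounds with values here, no measured compound carries hydroxy, so the direction is uncertain, but a modest drop from the higher number is the more likely outcome. The expected change is a 1.8-fold lower number from compound 2 to compound 3 (0.25 log units; within the scatter). For compound 3 the estimated value is 20 ug/mL, with an expected range of 6 ug/mL to 70 ug/mL.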

Compound 3, concentration for 50% growth inhibition: 4.2 ug/mL
The estimate for compound 3 lay 4.8-fold (0.68 log units) above the measured number; measured number outside the range, below it.
By their numbers in this assay, from the lowest: compounds 3 and 1 (each within the scatter of the next); then compound 2.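

In this assay the change from propyl to hydroxy on this aromatic carbon, para to a large group, gives an 8.4-fold lower number from compound 2 to compound 3 (0.93 log units; beyond the scatter) and so shows that this position can take a much lower number than compound 2 suggested on its own. Hydroxy and methylsulfanyl are not separated, since the step gives a 1.9-fold lower number from compound 1 to compound 3 (0.28 log units; within the scatter) and leaves the two groups level in this assay; of the three groups seen here, only propyl goes with clearly weaker inhibition of growth. No measurement shown here explains this difference between the groups.

On these data alone, it remains open whether a methoxy group or an amine at this position would sit with hydroxy and methylsulfanyl or with propyl. A methyl group or a longer chain would show whether the result for propyl extends to other carbon chains.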